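A few compounds are considered here, and "the series" means these few. Any claim that something is new, unique, unknown or untested is made for them only; others in the source may bear on it.

Measured in a functional assay on HepG2 cells (Homo sapiens) for inhibition, read by ATP content, with a stated time of 72 h; a higher number here means a weaker inhibitor, a lower number a stronger inhibitor:
- compound 1 `CCN(CC)c1ccc(NC(=O)CCCCCCC(=O)NO)cc1`: 2400 nM
- compound 2 `CCC(CC)CCNC(=O)c1ccc(NC(=O)CCCCCCC(=O)NO)cc1`: > 100000 nM (a limit, not a number)

On these data alone, compound 2 is known only as a limit in this assay, > 100000 nM, so its exact position on the scale is unknown. Compound 3 `CCN(CC)CCCNC(=O)c1ccc(NC(=O)CCCCCCC(=O)NO)cc1` differs from compound 2 in one place: (diethylamino)methyl in place of pentan-3-yl on a saturated chain carbon, two bonds along the chain from an amide-type nitrogen. This puts (diethylamino)methyl in place of pentan-3-yl on a saturated chain carbon, two bonds along the chain from an amide-type nitrogen. Going by the values given here, no measured step between closely matched compounds is available to guide this change. Compound 1, which also carries a diethylamino group, gives 2400 nM, so a large step towards a stronger inhibitor is expected. A limit cannot fix the size of that step. The estimated change is an at least 8.3-fold lower number from compound 2 to compound 3 (0.92 log units; beyond the scatter). For compound 3 the estimated value is 12000 nM, with an expected range of 2500 nM to 60000 nM.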

Compound 3, half-maximal inhibitory concentration: 8200 nM
For compound 3 the middle estimate is 1.5-fold (0.17 log units) above the measured one; low and high end bracket the measured number.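

In this assay, placing (diethylamino)methyl in place of pentan-3-yl on this saturated chain carbon turns a compound with no measurable number into one with a measurable number: an at least 12-fold lower number from compound 2 to compound 3 (1.08 log units; beyond the scatter). The change adds one nitrogen and leaves the carbon count as it was, so a difference of a single atom type, with the size of the group barely changed, is enough to produce a large step. The step is a minimum and not an exact size, since one end of it is a limit: the limit of > 100000 nM in this assay, at which 1 of the 3 values shown sits.

The compounds shown leave open whether this step needs the diethylamino group itself, or whether a dimethylamino group, a piperidine ring or a longer chain leading to the amine would serve as well. Compound 1 differs from compound 3 in more than one place, so the two cannot be compared directly.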